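This account rests on a few compounds, and the source may have more. Where it says the series, first, only, none or still open, it means among the compounds named here.

Values in a functional assay on microsomes for inhibition, with a stated time of 1 h; on this read-out higher numbers stand for weaker inhibition and lower numbers for stronger inhibition:
compound 1 `CSc1nc(-c2ccco2)c(C#N)c(=O)n1C`: 90 ug/mL
compound 2 `CSc1nc(-c2cccs2)c(C#N)c(=O)n1C`: 83 ug/mL
compound 3 `Cn1c(NN)nc(-c2cccs2)c(C#N)c1=O`: 68 ug/mL
compound 4 `Cn1c(NN)nc(-c2ccco2)c(C#N)c1=O`: not yet measured

Compound 3, at 68 ug/mL, stands within the scatter of both other compounds, so the three numbers cannot be ranked. Compound 4 differs from compound 3 as follows: furan-2-yl in place of thiophen-2-yl on an aromatic carbon. The same exchange, in the opposite direction and with methylsulfanyl on the core, appears as a 1.1-fold lower number from compound 1 to compound 2 (0.04 log units; within the scatter). The exchange of that group for aminoamino appears as a 1.2-fold lower number from compound 2 to compound 3 (0.09 log units; within the scatter). Among the compounds with values here, neither step leaves the scatter, although no measured pair shows the furan-2-yl and thiophen-2-yl exchange with aminoamino present. In this assay, no shift beyond the scatter is therefore expected in either direction. The expected change is a 1.1-fold higher number from compound 3 to compound 4 (0.04 log units; within the scatter). For compound 4, the estimated value is 74 ug/mL, with an expected range of 48 ug/mL to 112 ug/mL.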

Compound 4, half-maximal inhibitory concentration: 78 ug/mL
Compound 4: middle estimate off by 1.1-fold (0.02 log units), on the low side, within the range that was stated.
By their numbers in this assay, from the lowest: compounds 3, 4, 2 and 1 (each within the scatter of the next).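

In this assay, the exchange between furan-2-yl and thiophen-2-yl can now be read with aminoamino on the core, as a 1.1-fold higher number from compound 3 to compound 4 (0.06 log units; within the scatter), and it stays within the scatter as it did with methylsulfanyl: the same change on two cores in this assay, a 1.1-fold lower number (0.04 log units; within the scatter) from compound 1 to compound 2 and a 1.1-fold lower number (0.06 log units; within the scatter) from compound 4 to compound 3, 1.1-fold (0.02 log units) apart, within the scatter of two such steps. The exchange of methylsulfanyl for aminoamino can now be read with furan-2-yl present, as a 1.2-fold lower number from compound 1 to compound 4 (0.06 log units; within the scatter): the same change on two cores in this assay, a 1.2-fold lower number (0.09 log units; within the scatter) from compound 2 to compound 3 and a 1.2-fold lower number (0.06 log units; within the scatter) from compound 1 to compound 4, 1.1-fold (0.02 log units) apart, within the scatter of two such steps. Across these four compounds, neither exchange leaves the scatter on either core.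

Still open, from the compounds shown here alone, is whether a phenyl ring or a saturated amine such as morpholine in place of furan-2-yl would shift the number beyond the scatter. The same question holds for a longer alkylamine chain in place of aminoamino.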